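The source may report more compounds than this note shows. Statements on the series, on what has been measured and on what is new or still open speak of the compounds shown alone.

Measured compounds:
Compound 1 `COc1cccc(/C=N/Nc2ncc3c(n2)n(C2CCCC2)c(=O)c(=O)n3C)c1` — 20700 nM
Compound 2 `Cn1c(=O)c(=O)n(C2CCCC2)c2nc(N/N=C/c3ccccc3F)ncc21` — 27600 nM

In a functional assay on PC-3 cells (Homo sapiens) for antiproliferative activity, read by MTT assay (on this read-out higher numbers stand for weaker inhibition and lower numbers for stronger inhibition), compound 1 gives 20700 nM and compound 2 gives 27600 nM. Compound 2 thus holds the highest of the two numbers, with compound 1 nearest, and the gap between them lies within the scatter, so no order can be read into it. Among the compounds with values here, the one measured step, a 1.3-fold higher number from compound 1 to compound 2 (0.12 log units; within the scatter), swapped one aromatic ring for another on the carbon with a double bond to nitrogen and left the read-out essentially unchanged.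

Compound 3 `Cn1c(=O)c(=O)n(C2CCCC2)c2nc(N/N=C/c3cc([N+](=O)[O-])ccc3Cl)ncc21` has not yet been measured in this assay. It differs from compound 2 in that (2-chloro-5-nitrophenyl in place of 2-fluorophenyl on a carbon with a double bond to nitrogen). Within the data shown here, the only step that bears on it is a 1.3-fold higher number from compound 1 to compound 2 (0.12 log units; within the scatter), which was small; a further exchange of the aromatic ring at the same place is therefore expected to give a step of a 1.1-fold lower number from compound 2 to compound 3 (0.04 log units; within the scatter), not beyond the scatter in either direction. Compound 3 is accordingly estimated at 25000 nM, with a likely range from 8000 nM to 80000 nM.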

Compound 3, half-maximal inhibitory concentration: 9260 nM
Compound 3: middle estimate off by 2.7-fold (0.43 log units), on the high side, and the stated range covers the measured number.
By their numbers in this assay, from the lowest: compound 3; then compounds 1 and 2 (each within the scatter of the next).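

In this assay the aromatic ring on the carbon with a double bond to nitrogen turns out to be able to move the number: the step to 2-chloro-5-nitrophenyl (a 3.0-fold lower number from compound 2 to compound 3 (0.47 log units; beyond the scatter)) and the one from 3-methoxyphenyl (a 2.2-fold lower number from compound 1 to compound 3 (0.35 log units; beyond the scatter)) both lie beyond the scatter, whereas the earlier exchange of rings gave no readable change. Both steps are modest, so this position has so far shown a real but limited response across these three rings. Nothing at hand explains the shift.

Going by these compounds, the entering ring carries a chlorine and a nitro group together, so the share of each in the step remains open. Also open, on these data alone, is how the number would respond to a ring bearing an amine or a carboxylic acid at this place.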